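The source may report more compounds than this note shows. Statements on the series, on what has been measured and on what is new or still open speak of the compounds shown alone.

Working notes on the series.

Going by the values given here, compound 2 `CCCCCCCc1ccc(NC(=O)N[C@@H](C)c2ccccc2)cc1` gives, in an ADME assay on the whole organism with Oryza sativa as the target, tested at 10 uM (on this read-out higher numbers stand for a weaker effect at the one concentration tested and lower numbers for a stronger effect), 99%; this is the highest of the two numbers measured so far, but its nearest neighbour, compound 1 `CCc1ccc(NC(=O)N[C@@H](C)c2ccccc2)cc1`, gives 91% in this assay, and the step of a number 8 percentage points higher from compound 1 to compound 2 (within the scatter) lies within the scatter, so no order between the two can be claimed. Compound 3 `C[C@H](NC(=O)Nc1ccc(Br)cc1)c1ccccc1` has not yet been measured. It differs from compound 2 by bromo in place of heptyl on an aromatic carbon. Among the compounds with values here, the only measured step, a number 8 percentage points higher from compound 1 to compound 2 (within the scatter), concerns a change on a saturated chain carbon and stays within the scatter; no measured step touches a substituent on an aromatic carbon of the six-membered ring, so the change to compound 3 has no direct precedent here. Within the data shown here, with both measured values close together and the one known step within the scatter, the expectation for compound 3 in this assay is that the number moves by no more than the scatter, in either direction. The step from compound 2 expected from this reasoning is a number 6 percentage points lower from compound 2 to compound 3 (within the scatter). The estimate for compound 3 in this assay is 93%, with a range from 80% to 100%.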

Compound 3, a percentage reported as activity, at one concentration (the size of the read-out at that concentration, not a potency): 96%
The estimate for compound 3 lay 3 percentage points below the measured number, within the range that was stated.
By their numbers in this assay, from the lowest: compounds 1, 3 and 2 (each within the scatter of the next).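

In this assay, going by these compounds alone, the group on the aromatic carbon, para to a large group, now changes for the first time, whereas the earlier step concerned only the saturated chain. With a number 3 percentage points lower from compound 2 to compound 3 (within the scatter) for bromo in place of heptyl and a number 5 percentage points higher from compound 1 to compound 3 (within the scatter) for bromo in place of ethyl, neither exchange separates the compounds, so at this position a single bromine atom and a chain of either length cannot be told apart on this read-out, and the three compounds stand in no firm order. No measured evidence accounts for this result.

All the groups shown at this position are a halogen or a saturated carbon chain, so it remains open whether a group of another kind, such as an amine, a carboxylic acid or a nitrile, would give a number beyond the scatter from these three. As far as these compounds go, it is equally open whether any change at this position moves the read-out appreciably, or whether the numbers stay together for every group placed there.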